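Reversing the Amide Link: An Expectation for Compound 4

The source may hold more compounds than are shown below. What is called first, only, known or untested is meant among the compounds shown, and "the series" means these compounds.

Compound 1, `Cc1cc(C(=O)NC(C)C)nn1Cc1cc(Cl)ccc1OCc1ccccc1`: 126 nM
Compound 2, `Cc1cc(C(=O)Nc2c(F)cccc2F)nn1Cc1cc(Cl)ccc1OCc1ccccc1`: 10 nM
Compound 3, `Cc1cc(C(=O)NN2CCOCC2)nn1Cc1cc(Cl)ccc1OCC(C)C`: 251 nM

In an assay on CHO-K1 cells for displacement of a labelled ligand from prostaglandin E2 receptor EP1 subtype (Homo sapiens) (on this read-out lower numbers stand for stronger inhibition and higher numbers for weaker inhibition), compound 1 gives 126 nM, the second highest of the three numbers; compound 3 gives 251 nM, within the scatter of it. The only step beyond the scatter among these is a 13-fold lower number from compound 1 to compound 2 (1.10 log units; beyond the scatter), which replaces the group on the amide-type nitrogen.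

Compound 4, `Cc1cc(NC(=O)CC(C)(C)C)nn1Cc1cc(Cl)ccc1OCc1ccccc1`, differs from compound 1 by (neopentylcarbonyl)amino in place of isopropylcarbamoyl on an aromatic carbon. Among the measured compounds shown here, no measured pair turns the amide around in this way, and none carries a neopentyl chain, so that step does not bear on the change. With nothing to pull the number either way, compound 4 is expected to show no step beyond the scatter, a 2.0-fold higher number from compound 1 to compound 4 (0.30 log units; within the scatter). The estimate for compound 4 is 250 nM, with a range from 50 nM to 1500 nM.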

Compound 4, half-maximal inhibitory concentration: 10 nM
For compound 4 the middle estimate is 25-fold (1.40 log units) above the measured one, and the stated range ends above it.
By their numbers in this assay, from the lowest: compounds 2 and 4 (each within the scatter of the next); then compounds 1 and 3 (each within the scatter of the next).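

In this assay the exchange of isopropylcarbamoyl for (neopentylcarbonyl)amino gives a 13-fold lower number from compound 1 to compound 4 (1.10 log units; beyond the scatter) and shows that this aromatic carbon accepts a turned-around amide with a gain rather than a loss. The (2,6-difluorophenyl)carbamoyl group is not the only route to such a number here, since the exchange gives no change at the digits printed from compound 2 to compound 4 (within the scatter) even though (neopentylcarbonyl)amino holds no ring.

The compounds shown do not separate the turned-around link from the longer chain, and they leave open how a plain amine or a carboxylic acid on this carbon would read. No evidence at hand bears on the size of the step.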